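Adding a Methyl Group to Compound 1

This account rests on a few compounds, and the source may have more. Where it says the series, first, only, none or still open, it means among the compounds named here.

Compound 1 `COc1ccc(-n2c(=O)n(Cc3cc4cc(Cl)ccc4n3CCCC#N)c3cnccc32)cc1` was tested in an ADME assay on HeLa cells (Homo sapiens) for cytotoxicity, read by ATP content, with a stated time of 3 days; on this read-out higher numbers stand for lower toxicity in this test and lower numbers for higher toxicity in this test. In this assay compound 1 gives > 50000 nM, which is a limit of the assay rather than a number. Two further compounds were run in the same test. Compound 2 `CC(C)CCn1c(Cn2c(=O)n(C3CC3)c3ccncc32)cc2ccccc21` gives > 100000 nM in this assay, again a limit. Compound 3 `CC(C)CCn1c(Cn2c(=O)n(C3CC3)c3ccncc32)nc2cnccc21` likewise gives > 100000 nM in this assay, also a limit. None of the three compounds therefore returned a number: compound 1 stands at the limit of > 50000 nM in this assay, at which 1 of the 3 values shown sits, while the other two sit at the limit of > 100000 nM in this assay, at which 2 of the 3 values shown sit. Within the data shown here, no step between measured compounds that differ in one place is available, so nothing is known here about how a single change moves this read-out.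

Compound 4 `COc1ccc(-n2c(=O)n(Cc3cc4cc(Cl)ccc4n3CCCC#N)c3cnccc32)cc1C` differs from compound 1 by methyl in place of hydrogen on an aromatic carbon. Among the measured compounds shown here, with all three measured values sitting at limits and no measured step to draw on, the expected step that the limit leaves unreadable from compound 1 to compound 4 is none beyond the scatter, and the reading for compound 4 is expected most probably to remain a limit. Compound 4 is accordingly estimated at 60000 nM, with a range from 20000 nM to 200000 nM.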

Compound 4, half-maximal cytotoxic concentration: > 50000 nM
Compound 4: no number, only a limit; the forecaster's own chance of this, stated with the estimate: 80%; the middle value lies beyond the limit too.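

Compound 4, like compound 1, returned only a limit and no number in this assay, so the step between the two cannot be read: the limit of > 50000 nM in this assay, at which 2 of the 4 values shown sit.

The compounds shown leave open whether methyl in place of hydrogen on an aromatic carbon moves this read-out at all, and where the half-maximal cytotoxic concentration of any of them lies.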